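The compounds below may be only part of what the source reports. "The series", "measured", "known", "first", "only" and "open" are said of these compounds alone.

Measured so far:
compound 1 `Cc1ccc(-c2cs/c(=N/NC(=O)CSc3nnnn3-c3ccccc3)n2-c2ccccc2)cc1` — 22.2%
compound 2 `COc1ccc(-c2cs/c(=N/NC(=O)CSc3nnc(C)s3)n2-c2ccccc2)cc1` — 22.2%

In a functional assay on C6 cells (Rattus norvegicus) for cytotoxicity, read by MTT assay, with a stated time of 24 h, tested at 200 ug/mL (a lower number here means a stronger effect, a higher number a weaker effect of the compound at the concentration tested), compound 1 gives 22.2%. Compound 2 gives 22.2%, level with compound 1 at the digits shown, within the scatter. For the measured compounds named here, compound 2 differs from compound 1 in more than one place, so no single step is drawn between them.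

Compound 3 `O=C(CSc1nnnn1-c1ccccc1)N/N=c1/scc(-c2ccc(F)cc2)n1-c1ccccc1` is not yet measured. From compound 1 it differs by fluoro in place of methyl on an aromatic carbon. With two measured compounds standing level, no step beyond the scatter is expected; the step of a number 0.2 percentage points lower from compound 1 to compound 3 (within the scatter) is the estimate for compound 3. The value of compound 3 is expected near 22%, between 12% and 34%.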

Compound 3, a percentage reported as activity, at one concentration (the size of the read-out at that concentration, not a potency): 30.6%
The estimate for compound 3 lay 8.6 percentage points below the measured number; the measured number falls inside the stated range.
By their numbers in this assay, from the lowest: compounds 1, 2 and 3 (each within the scatter of the next).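

In this assay, fluoro in place of methyl on an aromatic carbon, para to a large group, gives a number 8.4 percentage points higher from compound 1 to compound 3 (within the scatter). This single-place comparison therefore does not separate the 4-methylphenyl and 4-fluorophenyl compounds at this position. No measurement is available that bears on this result.

Still open, from the compounds shown here alone, is whether an amine, a carboxylic acid or a longer chain at this position would give a step beyond the scatter. The compounds shown also leave open whether the same change would read alike with the other side chain of compound 2.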